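The compounds below may be only part of what the source reports. "The series", "measured", "known", "first", "only" and "open" are said of these compounds alone.

Among the measured compounds shown here, compound 2 `COc1cc(N(C)CCN(C)C)c(NC(=O)c2ccnc(Cl)c2)cc1Nc1nccc(-c2cn(C)c3ccccc23)n1` gives 970 nM in a functional assay on A549 cells (Homo sapiens) for antiproliferative activity, read by MTT assay, with a stated time of 72 h (on this read-out lower numbers stand for stronger inhibition and higher numbers for weaker inhibition), the lowest of the two numbers measured so far; compound 1 `COc1cc(N(C)CCN(C)C)c(NC(=O)c2ccncc2)cc1Nc1nccc(-c2cn(C)c3ccccc23)n1` gives 10400 nM, and the only recorded step is an 11-fold lower number from compound 1 to compound 2 (1.03 log units; beyond the scatter). Compound 3 `COc1cc(N(C)C)c(NC(=O)c2ccnc(Cl)c2)cc1Nc1nccc(-c2cn(C)c3ccccc23)n1` differs from compound 2 by hydrogen in place of (dimethylamino)methyl on a saturated chain carbon bound to a nitrogen on an aromatic ring; cut one bond further out this reads 2-(dimethylamino)ethyl to methyl, or (2-(dimethylamino)ethyl)(methyl)amino to dimethylamino. For the measured compounds named here, no measured step touches this part of the series: the one step known concerns a chloro in place of hydrogen on an aromatic carbon, so it offers no guide to shortening the chain. Any expectation for compound 3 in this assay therefore rests on no precedent and carries wide bounds. For compound 3 the expected number is 2000 nM, with a range of 500 nM to 8000 nM. The expected step is a 2.1-fold higher number from compound 2 to compound 3 (0.31 log units; beyond the scatter), of uncertain direction.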

Compound 3, half-maximal inhibitory concentration: 3430 nM
The estimate for compound 3 lay 1.7-fold (0.23 log units) below the measured number; the measured number falls inside the stated range.
By their numbers in this assay, from the lowest: compound 2; then compound 3; then compound 1.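

In this assay, cutting (2-(dimethylamino)ethyl)(methyl)amino back to dimethylamino gives a 3.5-fold higher number from compound 2 to compound 3 (0.55 log units; beyond the scatter), which makes this side chain a second place in the series where a single change moves the number beyond the scatter. Losing the (dimethylamino)methyl part weakens inhibition in this pair without abolishing it, and the step is smaller than the chloro step, an 11-fold lower number from compound 1 to compound 2 (1.03 log units; beyond the scatter), elsewhere on the series. Nothing available bears on the reason for the rise.

Still open, going by these compounds, is whether a longer chain, or a cyclic amine such as piperidine or morpholine, at this position would give a lower number than compound 2 does. Also open, on these data alone, is whether the chain step keeps its size in a pair without the chloro.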